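Chain extension on the shared core, compound 2 to compound 4

This account rests on a few compounds, and the source may have more. Where it says the series, first, only, none or still open, it means among the compounds named here.

Three members of the series have been measured so far, all in a functional assay on MKN-45 cells (Homo sapiens) for cytotoxicity, read by MTT assay, with a stated time of 48 h; a lower number here means a stronger inhibitor, a higher number a weaker inhibitor. Compound 1 `CCOC(=O)CSc1nnc(C)n1N1C(=O)c2ccccc2C1=O` returns only the assay limit, > 200000 nM. Compound 2 `Cc1nnc(SCC(=O)c2ccccc2)n1N1C(=O)c2ccccc2C1=O` likewise returns only the limit, > 200000 nM. Compound 3 `CSc1nnc(C)n1N1C(=O)c2ccccc2C1=O` also returns only the limit, > 200000 nM. The three steps among them, a step that the two limits leave unreadable from compound 1 to compound 2, a step that the two limits leave unreadable from compound 1 to compound 3 and a step that the two limits leave unreadable from compound 2 to compound 3, therefore have no readable size; what they share is the limit of > 200000 nM in this assay, at which 3 of the 3 values shown sit.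

Compound 4 `CCCc1nnc(SCC(=O)c2ccccc2)n1N1C(=O)c2ccccc2C1=O` differs from compound 2 by ethyl in place of hydrogen on a saturated chain carbon bound to an aromatic carbon. Within the data shown here, none of the measured steps touches this carbon; all three alter the chain on the sulfur. Among the measured compounds shown here, nothing measured gives a footing for a change in either direction, and every value so far sits at the limit. The expected step is a step that the limit leaves unreadable from compound 2 to compound 4, i.e. no change beyond the scatter, most probably again a limit rather than a number. The estimate for compound 4 is 300000 nM, expected to lie between 100000 nM and 2000000 nM.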

Compound 4, half-maximal inhibitory concentration: > 200000 nM
Compound 4: only a limit was reported; the forecaster's own chance of this, stated with the estimate: 85%; the middle value lies beyond the limit too.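

Compound 2 and compound 4 both return only a limit, so no step can be read from compound 2 to compound 4: the limit of > 200000 nM in this assay, at which 4 of the 4 values shown sit.

The compounds shown leave open whether the chain on the sulfur, or propyl in place of methyl, bears on the read-out at all.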